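The source may hold more compounds than are shown below. What is called first, only, known or untested is meant among the compounds shown, and "the series" means these compounds.

Of the compounds shown here, two have so far been measured in a toxicity assay on Huh-7.5 cells (Homo sapiens) for inhibition, read by MTT assay, with a stated time of 96 h; a higher number here means that more compound is tolerated, a lower number that less compound is tolerated. Compound 1, `CN(C)C1CCN(Cc2ccc(NC(=O)c3ccc(OCCCCl)c([N+](=O)[O-])c3)cc2C(F)(F)F)CC1`, gives 5500 nM in this assay. Compound 2, `CCC(=O)Nc1cc(C(=O)Nc2ccc(N(C)C)cc2)ccc1OC`, gives 171000 nM in this assay. Of these two numbers, compound 1 has the lower one, and the gap to compound 2 lies beyond the usual scatter, so the cells tolerate less of compound 1 than of compound 2. Compound 2 shares little of its structure with compound 1, so its value tells nothing about any single structural change.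

The compound that has not yet been measured is compound 3, `CN(C)C1CN(Cc2ccc(NC(=O)c3ccc(OCCCCl)c([N+](=O)[O-])c3)cc2C(F)(F)F)C1`. It differs from compound 1 in one place: 3-(dimethylamino)azetidin-1-yl in place of 4-(dimethylamino)piperidin-1-yl on a saturated chain carbon bound to an aromatic carbon. Everything else in the molecule stays the same. For the measured compounds named here, no measured pair in this set shows what trading one of these two groups for the other does, so the expectation rests only on the change itself, which is small and keeps the same count of hydrogen-bond donors and acceptors. The step of a 1.1-fold higher number from compound 1 to compound 3 (0.04 log units; within the scatter) is expected to stay within the usual scatter. Compound 3 is therefore estimated at 6000 nM, with a range from 2500 nM to 15000 nM.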

Compound 3, half-maximal cytotoxic concentration: 7800 nM
Beside the measured number, compound 3's estimate is 1.3-fold (0.11 log units) below it, within the range that was stated.
By their numbers in this assay, from the lowest: compounds 1 and 3 (each within the scatter of the next); then compound 2.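

In this assay, for the compounds shown here, the one pair in this set that differs in a single place gives a 1.4-fold higher number from compound 1 to compound 3 (0.15 log units; within the scatter) and so offers the first direct reading of a structural change. On this saturated chain carbon bound to an aromatic carbon, the six-membered ring of 4-(dimethylamino)piperidin-1-yl can be replaced by the four-membered ring of 3-(dimethylamino)azetidin-1-yl without a change in the tolerated concentration that can be told apart from repeat-measurement noise, at least for this core. No measurement at hand offers an explanation for this result.

This is a single exchange between two ring amines in one cell assay, so it cannot show how far the result extends to other groups at the same place, such as morpholin-4-yl, an open-chain amine or a carboxylic acid. It also leaves open whether the same exchange would behave in the same way on a different core, or whether changes elsewhere in compound 1, such as to its chloropropyl ether chain, would shift the number more.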